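A Fluorine on the Benzoyl Ring of a Chemokine Receptor Ligand

This account rests on a few compounds, and the source may have more. Where it says the series, first, only, none or still open, it means among the compounds named here.

Compound 1, `O=C(NCc1ccc(CNS(=O)(=O)c2ccccc2)cc1)c1ccc([N+](=O)[O-])cc1`: 100 nM
Compound 2, `Cc1ccc(S(=O)(=O)NCc2ccc(CNC(=O)c3c(Cl)cc(Cl)cc3Cl)cc2)cc1`: 10 nM
Compound 3, `Cc1ccc(S(=O)(=O)NCc2ccc(CNC(=O)c3ccccc3)cc2)cc1`: > 1000 nM

In an assay on MDA-MB-231 cells for binding affinity to C-X-C chemokine receptor type 4 (Homo sapiens), read by immunofluorescence and microscopy, with stated times of 10 min and 30 min (a lower number here means that less compound is needed, a higher number that more compound is needed for the effect), compound 2 gives 10 nM, and compound 1 gives 100 nM. For compound 3 the assay reports only a limit, > 1000 nM. Compound 3 thus stands at the weak end of the three measured compounds, sitting at the limit of > 1000 nM in this assay, at which 1 of the 3 values shown sits. Among the compounds with values here, the one measured change on the carbonyl carbon is an at least 100-fold higher number from compound 2 to compound 3 (2.00 log units; beyond the scatter), a large step.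

Compound 4, `Cc1ccc(S(=O)(=O)NCc2ccc(CNC(=O)c3ccc(F)cc3)cc2)cc1`, differs from compound 3 in a single place: fluoro in place of hydrogen on an aromatic carbon. Within the data shown here, only the step from compound 2 to compound 3 bears on this change, and it shows that the ring on the carbonyl carbon can shift the number a great deal; yet the entering fluoro is a single heavy atom, far less than the three chlorines of compound 2. A modest move toward a lower number is therefore expected for compound 4, an at least 1.4-fold lower number from compound 3 to compound 4 (0.15 log units; that floor lies within the scatter), though the result may again be a limit. The estimate for compound 4 in this assay is 700 nM, expected to fall between 150 nM and 3000 nM.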

Compound 4, effective concentration (reported as EC, without a stated level of effect): 1 nM
The estimate for compound 4 lay 700-fold (2.85 log units) above the measured number; the whole stated range lies above it.
By their numbers in this assay, from the lowest: compound 4; then compound 2; then compound 1. At a limit, above all of these: compound 3.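

A single fluoro, para to a large group on the benzoyl ring, gives an at least 1000-fold lower number from compound 3 to compound 4 (3.00 log units; beyond the scatter) in this assay, so at this position one added atom can move the number as far as any change seen so far. The further step, a 10-fold lower number from compound 2 to compound 4 (1.00 log units; beyond the scatter), shows that the three chlorines of compound 2 are not required for a low number, as the 4-fluorophenyl group alone goes beyond them. The first of these steps is only a floor, since compound 3 stands at a limit: the limit of > 1000 nM in this assay, at which 1 of the 4 values shown sits.

As far as these compounds go, what remains open is whether this step belongs to fluoro in particular, or whether a methoxy group, an amine or a carboxylic acid on the same aromatic carbon would move the number as well. From the compounds shown here alone, it is also open whether the same change would carry over to the core of compound 1.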